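The source may report more compounds than this note shows. Statements on the series, on what has been measured and on what is new or still open speak of the compounds shown alone.

Working notes on the series. In an ADME assay on microsomes from liver (Rattus norvegicus) for metabolic stability, read by LC-MS, using NADPH, with stated times of 5 min and 60 min, tested at 4 uM (on this read-out lower numbers stand for a less stable compound and higher numbers for a more stable compound), compound 1 `CC1=C(c2nc(-c3ccc(C#N)cc3)cs2)C(c2ccc(F)nc2)NC(=O)N1` gives 49.4%, compound 2 `CC1=C(c2nc(-c3ccc(C#N)cc3)cs2)C(c2ccc(Cl)nc2)NC(=O)N1` gives 63.4% and compound 3 `CC1=C(c2nc(-c3ccc(C#N)cc3)cs2)C(c2ccc(Br)nc2)NC(=O)N1` gives 67.6%. Compound 2 is thus level with compound 3 within the scatter and lies beyond the scatter from compound 1. Compound 4 `COc1ccc(C2NC(=O)NC(C)=C2c2nc(-c3ccc(C#N)cc3)cs2)cc1` differs from compound 2 as follows: 4-methoxyphenyl in place of 6-chloropyridin-3-yl on a saturated ring carbon. The measured steps change only the halogen on the aromatic ring: a number 14 percentage points higher from compound 1 to compound 2 (beyond the scatter), a number 18.2 percentage points higher from compound 1 to compound 3 (beyond the scatter) and a number 4.2 percentage points higher from compound 2 to compound 3 (within the scatter). None replaces the whole group, so they indicate size only, and no measurement fixes the direction. A modest fall is tentatively expected, with the change estimated as a number 15.4 percentage points lower from compound 2 to compound 4 (beyond the scatter). The estimate for compound 4 is 48%, with an expected range of 26% to 70%.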

Compound 4, percent of the compound remaining: 63.2%
Compound 4: the middle estimate sits 15.2 percentage points below what was measured; the range from low to high includes it.
By their numbers in this assay, from the lowest: compound 1; then compounds 4, 2 and 3 (each within the scatter of the next).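

At this saturated ring carbon in this assay, the whole aryl group can be exchanged without a step beyond the scatter from two of the halopyridines: 4-methoxyphenyl in place of 6-chloropyridin-3-yl gives (a number 0.2 percentage points lower from compound 2 to compound 4 (within the scatter)), and in place of 6-bromopyridin-3-yl gives (a number 4.4 percentage points lower from compound 3 to compound 4 (within the scatter)). A ring of carbon only therefore stands level with compound 2 and compound 3, whereas in place of 6-fluoropyridin-3-yl the step is larger (a number 13.8 percentage points higher from compound 1 to compound 4 (beyond the scatter)). Nothing available explains this result. As far as these compounds go, whether unsubstituted phenyl would stand level too remains open. So does the outcome with an amine, a carboxylic acid or a longer chain in place of the methoxy group.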